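Amide tail variation and cytotoxicity across three analogues

This account rests on a few compounds, and the source may have more. Where it says the series, first, only, none or still open, it means among the compounds named here.

In an ADME assay on MT4 cells (Homo sapiens) for cytotoxicity, read by MTT assay (on this read-out higher numbers stand for lower toxicity in this test and lower numbers for higher toxicity in this test), compound 3 `Cc1cc(C)cc(S(=O)(=O)c2c(C(=O)NC(C)C(=O)NCc3ccncn3)[nH]c3ccc(Cl)cc23)c1` gives 28100 nM, the highest of the three numbers measured. Compound 2 `Cc1cc(C)cc(S(=O)(=O)c2c(C(=O)NC(C)C(=O)NCc3ccccc3F)[nH]c3ccc(Cl)cc23)c1` gives 23300 nM and compound 1 `Cc1cc(C)cc(S(=O)(=O)c2c(C(=O)NC(C)C(=O)NC(C)c3ccncc3)[nH]c3ccc(Cl)cc23)c1` gives 21900 nM; all three sit within the scatter of one another, as the steps show: a 1.1-fold higher number from compound 1 to compound 2 (0.03 log units; within the scatter), a 1.3-fold higher number from compound 1 to compound 3 (0.11 log units; within the scatter) and a 1.2-fold higher number from compound 2 to compound 3 (0.08 log units; within the scatter). Compound 4 `Cc1cc(C)cc(S(=O)(=O)c2c(C(=O)NC(C)C(=O)NCCn3c(C)cnc3[N+](=O)[O-])[nH]c3ccc(Cl)cc23)c1` differs from compound 3 in the group on a saturated chain carbon bound to an amide-type nitrogen: a group of 10 heavy atoms (5 carbon, 3 nitrogen, 2 oxygen; one five-membered aromatic ring with 2 hetero atoms) in place of a group of 6 heavy atoms (4 carbon, 2 nitrogen; one six-membered aromatic ring with 2 hetero atoms), on a saturated chain carbon bound to an amide-type nitrogen. For the measured compounds named here, the single measured step at this place, from compound 2 to compound 3, stayed within the scatter, and the two steps on the amide-type nitrogen itself did likewise. No measured change in this part of the molecule has moved the number beyond the scatter, so no step beyond the scatter is expected here either. Compound 4 is therefore estimated at 25000 nM, with a range of 12000 nM to 50000 nM. That estimate means an expected step of a 1.1-fold lower number from compound 3 to compound 4 (0.05 log units; within the scatter).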

Compound 4, half-maximal cytotoxic concentration: 16000 nM
Compound 4: the middle estimate sits 1.6-fold (0.19 log units) above what was measured; the range from low to high includes it.
By their numbers in this assay, from the lowest: compounds 4, 1, 2 and 3 (each within the scatter of the next).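

Exchanging the earlier six-membered aromatic rings for a group of 10 heavy atoms with one five-membered aromatic ring leaves the numbers in this assay together, with all three new steps printed as within the scatter: (a 1.8-fold lower number from compound 3 to compound 4 (0.24 log units; within the scatter)), (a 1.5-fold lower number from compound 2 to compound 4 (0.16 log units; within the scatter)) and (a 1.4-fold lower number from compound 1 to compound 4 (0.14 log units; within the scatter)). Until now, this place on a saturated chain carbon bound to an amide-type nitrogen had shown only pyrimidin-4-yl and 2-fluorophenyl, so the flat read-out now extends to a different ring size, a larger group, 1 double bond outside aromatic rings and 4 hydrogen-bond acceptors.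

Going by these compounds, an amine, a carboxylic acid or a longer chain without a ring at this place remains open, so the limits of this flat read-out are not yet known. No accompanying data bear on the cause of these numbers.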